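The source may report more compounds than this note shows. Statements on the series, on what has been measured and on what is new or still open speak of the compounds shown alone.

Values measured in an ADME assay on cells (Peritoneal macrophage, Mus musculus, strain Swiss) for cytotoxicity, with a stated time of 24 h (a lower number here means that less compound is tolerated, a higher number that more compound is tolerated), so far:

Compound 1 `O=C1C=CC(=O)c2c1ccc(I)c2O` gives > 100000 nM
Compound 2 `COc1c(I)ccc2c1C(=O)C=CC2=O` gives 13300 nM
Compound 3 `Cc1cc(I)c2c(c1)C(=O)C=CC2=O` gives 12100 nM

The entry for compound 1, > 100000 nM, is a limit and not a number. Among the measured compounds shown here, only two compounds therefore have numbers: compound 2 at 13300 nM and compound 3 at 12100 nM. These two lie within the scatter of each other, so compound 2 stands level with compound 3.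

Compound 4 `Nc1c(I)ccc2c1C(=O)C=CC2=O` has not yet been measured. It carries amino in place of methoxy on an aromatic carbon, ortho to an iodo group (amino in place of methoxy on an aromatic carbon).

For the measured compounds named here, one measured step bears on this place. In an at least 7.5-fold lower number from compound 1 to compound 2 (0.87 log units; beyond the scatter), beyond the scatter, methyl takes the place of hydrogen on the oxygen of the aromatic ring. Going by the values given here, compound 4 likewise lacks that methyl, but amino is not the hydroxyl of compound 1, and no measured step covers amino itself. A move toward better tolerance is thus expected, though only part of the size of an at least 7.5-fold lower number from compound 1 to compound 2 (0.87 log units; beyond the scatter). The expected change is a 2.3-fold higher number from compound 2 to compound 4 (0.35 log units; beyond the scatter). Compound 4 is estimated at 30000 nM, with an expected range from 8000 nM to 100000 nM.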

Compound 4, concentration lethal to 50% of the cells: 13100 nM
Compound 4: the middle estimate sits 2.3-fold (0.36 log units) above what was measured; the range from low to high includes it.
By their numbers in this assay, from the lowest: compounds 3, 4 and 2 (each within the scatter of the next). At a limit, above all of these: compound 1.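

In this assay, amino in place of methoxy on this aromatic carbon, ortho to an iodo group, gives a 1.0-fold lower number from compound 2 to compound 4 (0.01 log units; within the scatter), so the read-out does not tell these two groups apart, although they differ in their count of hydrogen-bond donors. Amino in place of hydroxy at the same carbon gives an at least 7.6-fold lower number from compound 1 to compound 4 (0.88 log units; beyond the scatter), which, read with an at least 7.5-fold lower number from compound 1 to compound 2 (0.87 log units; beyond the scatter), leaves hydroxy as the one group of the three at this place that stands apart from the other two. The entry for compound 1 is a limit and not a number, so both steps from it give a bound and not a size: the limit of > 100000 nM in this assay, at which 1 of the 4 values shown sits.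

The compounds shown leave open whether a larger group on the nitrogen, such as dimethylamino or an acetamide, or a carboxylic acid at this carbon would stay level with compound 2 and compound 4 or move toward compound 1. They also leave open whether amino and methoxy would still match with chloro or hydrogen in place of the iodo group.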